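Adding a methoxy to the phenethyl side chain of compound 1

The source may hold more compounds than are shown below. What is called first, only, known or untested is meant among the compounds shown, and "the series" means these compounds.

Compound 1 `Cc1nn(-c2ncnc3nc[nH]c23)c2c1C(OCCc1ccccc1)CC(=O)N2` is an agonist of its receptor: in a functional assay on HEK293 cells for agonist activity at G-protein coupled receptor 39 (Homo sapiens), read by scintillation proximity assay and inositol phosphate accumulation, with a stated time of 75 min, in the presence of a further agent that is not named here (a lower number here means that less compound is needed, a higher number that more compound is needed for the effect), compound 1 gives 3 nM. Its nearest measured neighbour, compound 2 `Cc1nn(-c2ncnc3nc[nH]c23)c2c1C(NC(=O)Cc1cccs1)CC(=O)N2`, gives 3 nM in this assay, and the step of no change at the digits printed from compound 1 to compound 2 (within the scatter) lies within the scatter, so compound 1 stands level with compound 2 on the numbers shown.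

Compound 3 `COc1ccc(CCOC2CC(=O)Nc3c2c(C)nn3-c2ncnc3nc[nH]c23)cc1` differs from compound 1 in one place: methoxy in place of hydrogen on an aromatic carbon. Among the compounds with values here, the only measured step, from compound 1 to compound 2, swaps the whole side chain on the saturated ring carbon and says nothing about a methoxy on the aromatic ring, so no measured step bears directly on this change. With no evidence either way, the step of no change at the digits printed from compound 1 to compound 3 (within the scatter) is expected to stay within the scatter. The estimate for compound 3 in this assay is therefore 3 nM, with a range from 1 nM to 10 nM.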

Compound 3, half-maximal effective concentration: 2 nM
The estimate for compound 3 lay 1.5-fold (0.18 log units) above the measured number; low and high end bracket the measured number.
By their numbers in this assay, from the lowest: compounds 3, 1 and 2 (each within the scatter of the next).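

In this assay the methoxy brings a 1.5-fold lower number from compound 1 to compound 3 (0.18 log units; within the scatter) and so shows that the aromatic carbon para to a large group can carry 2 further heavy atoms without the number leaving the scatter. Compound 1 and compound 2 spoke only to a swap of the whole side chain on the saturated ring carbon, whereas compound 3 speaks to a single substitution on the ring of that chain, with phenethyl and 2-(4-methoxyphenyl)ethyl reading alike. Nothing measured here accounts for this outcome.

On these data alone, whether a fluorine, a hydroxyl, a dimethylamino group or a carboxylic acid on the same carbon would read alike stays open, as does a methoxy on any other carbon of this ring. A longer chain between the ring and the ether oxygen also remains an open question.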